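The source may hold more compounds than are shown below. What is called first, only, known or untested is meant among the compounds shown, and "the series" means these compounds.

In a functional assay on A-375 cells (Homo sapiens) for antiproliferative activity, read by trypan blue exclusion, with a stated time of 48 h, tested at 10 uM (a lower number here means a stronger effect, a higher number a weaker effect of the compound at the concentration tested), compound 3 `CCCCCCC#Cc1ccc(S(=O)(=O)Nc2cccc(-c3csc(NC)n3)c2)cc1` gives 1.2%, the lowest of the three numbers in hand. Compound 2 `CC(=O)Nc1nc(-c2cccc(NS(=O)(=O)c3cccc(C#C[Si](C)(C)C)c3)c2)cs1` gives 5.8%, which sits within the scatter of the number for compound 3, so no order between the two can be read. Compound 1 `CC(=O)Nc1nc(-c2cccc(NS(=O)(=O)c3ccc(C#CCO)cc3)c2)cs1` gives 48.8%, a number beyond the scatter above that of compound 3. Compound 4 `CCCCCCC#Cc1ccc(S(=O)(=O)Nc2cccc(-c3csc(N)n3)c2)cc1` has not yet been measured. It differs from compound 3 in one place: hydrogen in place of methyl on a nitrogen on an aromatic ring. Within the data shown here, no measured pair shows this change, so its effect is unknown. Because compound 3 gives 1.2% there is little room to go lower. The step of a number 2.8 percentage points higher from compound 3 to compound 4 (within the scatter) is expected to stay within the scatter. Compound 4 is estimated to give 4%, with a range of 0% to 20%.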

Compound 4, a percentage reported as activity, at one concentration (the size of the read-out at that concentration, not a potency): 3.5%
The estimate for compound 4 lay 0.5 percentage points above the measured number, and the stated range covers the measured number.
By their numbers in this assay, from the lowest: compounds 3, 4 and 2 (each within the scatter of the next); then compound 1.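

In this assay, among these compounds, putting hydrogen in place of methyl on a nitrogen on an aromatic ring gives a number 2.3 percentage points higher from compound 3 to compound 4 (within the scatter), the first reading of this change. The methylamino and amino forms therefore cannot be told apart at this position, and both numbers lie close to the bottom of the read-out. Nothing on hand accounts for this result.

From the compounds shown here alone, whether an ethyl group or a longer alkyl chain on this nitrogen would read the same remains open. So does whether compound 3 and compound 4 would separate at a lower concentration.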